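A few compounds are considered here, and "the series" means these few. Any claim that something is new, unique, unknown or untested is made for them only; others in the source may bear on it.

In a functional assay on HepG2 cells (Homo sapiens) for antiproliferative activity, read by MTT assay, with a stated time of 72 h (on this read-out higher numbers stand for weaker inhibition and lower numbers for stronger inhibition), compound 2 `O=C1COc2ccc(-c3cnc4ccccc4c3)cc2N1C1CCCCC1` gives > 40000 nM, which is a limit of the assay and not a number. Compound 1 `CC(C)N1C(=O)COc2ccc(-c3cccc(NS(=O)(=O)c4ccc(F)cc4)c3)cc21` gives > 40000 nM, also a limit. Compound 3 `O=C1COc2ccc(-c3cccc(NS(=O)(=O)c4ccc(F)cc4)c3)cc2N1C1CC1` gives > 40000 nM, again a limit. Together these values leave (the limit of > 40000 nM in this assay, at which 3 of the 3 values shown sit). Compound 4 `O=C1COc2ccc(-c3cnc4ccccc4c3)cc2N1` has not yet been measured and differs from compound 2 by one change: hydrogen in place of cyclohexyl on an amide-type nitrogen in a ring. Hydrogen thus replaces cyclohexyl on an amide-type nitrogen in a ring. Within the data shown here, the one measured step on such a nitrogen is a step that the two limits leave unreadable from compound 1 to compound 3, so it offers no size to carry over. No clear direction can therefore be expected, and the estimated step is a number no higher from compound 2 to compound 4 (the limit leaves the size open). Compound 4 is expected near 40000 nM, with an estimated range from 15000 nM to 100000 nM.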

Compound 4, half-maximal inhibitory concentration: 26300 nM
For compound 4 the middle estimate is 1.5-fold (0.18 log units) above the measured one; the measured number falls inside the stated range.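

On the amide-type nitrogen, hydrogen in place of cyclohexyl gives an at least 1.5-fold lower number from compound 2 to compound 4 (0.18 log units; that floor lies within the scatter) in this assay. Among these compounds, this is the first step on this nitrogen with a readable lower bound, yet that bound does not show a real change, and the true size stays open. Compound 4 is the only compound shown with a measured number, and the rest stay at a limit: the limit of > 40000 nM in this assay, at which 3 of the 4 values shown sit.

As far as these compounds go, whether a methyl or an ethyl group on this nitrogen would give a number also remains open. So does whether hydrogen there would give a number on the core of compound 1.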